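The compounds below may be only part of what the source reports. "The series", "measured", "known", "first", "only" and "open" are said of these compounds alone.

Working notes on the series. Compound 1 `O=C(Cn1c(=O)c(/C=C\c2ccncc2)nc2ccccc21)Nc1ccc(Cl)cc1` carries an unsubstituted chlorophenyl amide on the shared core. In a functional assay on HeLa cells (Homo sapiens) for inhibition, read by MTT assay, with a stated time of 24 h (on this read-out lower numbers stand for stronger inhibition and higher numbers for weaker inhibition), compound 1 returns only a limit, > 100000 nM. Compound 2 `O=C(Cn1c(=O)c(/C=C\c2ccncc2)nc2ccccc21)Nc1ccc(Cl)c(Cl)c1` adds a second chloro. In this assay compound 2 likewise returns only a limit, > 100000 nM. The step that the two limits leave unreadable from compound 1 to compound 2 therefore cannot be sized; both values sit at the limit of > 100000 nM in this assay, at which 2 of the 2 values shown sit, so compound 2 stands at the limit, with nothing measured beyond it.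

Compound 3 `COc1ccc(NC(=O)Cn2c(=O)c(/C=C\c3ccncc3)nc3ccccc32)cc1OC` changes the amide aryl: 3,4-dimethoxyphenyl in place of 3,4-dichlorophenyl on an amide-type nitrogen. Going by the values given here, no measured step bears on this change; the only step on record is a step that the two limits leave unreadable from compound 1 to compound 2, which the two limits leave unreadable. With both measured compounds at the limit, the step from compound 2 to compound 3 is expected to be a step that the limit leaves unreadable from compound 2 to compound 3, with a high chance that the assay again reports only a limit. For compound 3 in this assay the estimate is 150000 nM, within 40000 nM to 500000 nM.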

Compound 3, half-maximal inhibitory concentration: > 100000 nM
Compound 3: no number, only a limit; the forecaster's own chance of this, stated with the estimate: 70%; the middle value does not contradict the limit.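

No step can be read among compound 1, compound 2 and compound 3, because each returns only a limit: the limit of > 100000 nM in this assay, at which 3 of the 3 values shown sit.

The compounds shown leave open whether any amide aryl on the shared core reaches a measurable value in this assay and how these aryl groups would rank there.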